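The source may report more compounds than this note shows. Statements on the series, on what has been measured and on what is new or still open speak of the compounds shown alone.

Compound 1 `COc1ccc2cc(C(C)c3nnc4n3N=C(c3ccc([N+](=O)[O-])cc3)CS4)ccc2c1` and compound 2 `COc1ccc2cc(C(C)c3nnc4n3N=C(c3ccc(C(F)(F)F)cc3)CS4)ccc2c1` share one core; compound 3 `CC(C)Cc1ccc(C(C)c2nnc3n2N=C(c2ccc([N+](=O)[O-])cc2)CS3)cc1` and compound 4 `CC(C)Cc1ccc(C(C)c2nnc3n2N=C(c2ccc(C(F)(F)F)cc2)CS3)cc1` share another. The difference between the two cores is not broken down here.

In a functional assay on MCF7 cells (Homo sapiens) for inhibition, read by sulforhodamine B assay, with a stated time of 72 h (on this read-out higher numbers stand for weaker inhibition and lower numbers for stronger inhibition), compound 1 gives 18800 nM, and compound 2 gives 6900 nM. The step between them, a 2.7-fold lower number from compound 1 to compound 2 (0.44 log units; beyond the scatter), comes from one change, (trifluoromethyl in place of nitro on an aromatic carbon).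

In this assay compound 3 gives "not active" (no number reported), so no number stands for it. The change from compound 3 to compound 4 is trifluoromethyl in place of nitro on an aromatic carbon. Among the compounds shown this change occurs twice, on the same place both times, so it is the same change made on a second core.

On the first core the change gave a modest step toward stronger inhibition. Whether the same holds on the second core is not known; compound 3 supplies no number from which a step could be counted, and the two cores are not compared in any measured way. The expectation for compound 4 therefore rests only on the weak starting point of compound 3 and on the modest size of the step seen from compound 1 to compound 2. Compound 4 is expected to inhibit only weakly in this assay, with an estimated value of 40000 nM, somewhere between 10000 nM and 150000 nM, and a real chance that only a limit is reported.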

Compound 4, half-maximal inhibitory concentration: 4200 nM
For compound 4 the middle estimate is 9.5-fold (0.98 log units) above the measured one; the measured number lies below the stated range.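

Among the compounds shown here, compound 3 has no number in this assay, so no step to compound 4 can be read, although compound 4 gives 4200 nM. No available evidence bears on this result. The compounds shown leave open whether trifluoromethyl in place of nitro has a step of similar size on the core of compound 3 as on the core of compound 1, and how the two cores compare.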